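Hydroxamate chain length on two cores in cell growth

The compounds below may be only part of what the source reports. "The series", "measured", "known", "first", "only" and "open" are said of these compounds alone.

Notes on the series in a functional assay on Hep 3B2 cells (Homo sapiens) for inhibition, read by MTT assay, with a stated time of 72 h; a higher number here means a weaker inhibitor, a lower number a stronger inhibitor.

Compound 1 `Nc1ncnc2c1c(-c1cnc3[nH]ccc3c1)nn2CCCCCC(=O)NO` carries the hydroxycarbamoyl chain on its core. In this assay compound 1 gives > 50000 nM, which is a limit of the assay and not a number. Compound 2 `Nc1ncnc2c1c(-c1cnc3[nH]ccc3c1)nn2CCCCCCC(=O)NO` differs from it by (hydroxycarbamoyl)methyl in place of hydroxycarbamoyl on a saturated chain carbon, five bonds along the chain from an aromatic nitrogen. In this assay compound 2 gives 26300 nM. The step is an at least 1.9-fold lower number from compound 1 to compound 2 (0.27 log units; that floor lies within the scatter), and it has only a floor due to the limit of > 50000 nM in this assay, at which 1 of the 3 values shown sits.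

Compound 3 `Nc1nc2cc(-c3nn(CCCCC(=O)NO)c4ncnc(N)c34)ccc2o1` is built on another core; how the two cores differ is not broken down here. In this assay compound 3 gives 33700 nM, which against compound 2 lies within the scatter.

Compound 4 `Nc1nc2cc(-c3nn(CCCCCC(=O)NO)c4ncnc(N)c34)ccc2o1` is not yet measured. It differs from compound 3 by (hydroxycarbamoyl)methyl in place of hydroxycarbamoyl on a saturated chain carbon, four bonds along the chain from an aromatic nitrogen. This is the same kind of change as from compound 1 to compound 2, not the same: there the place is five bonds along the chain from an aromatic nitrogen, here four bonds along the chain from an aromatic nitrogen. The step expected here, a 1.7-fold lower number from compound 3 to compound 4 (0.23 log units; within the scatter), rests on the earlier step of an at least 1.9-fold lower number from compound 1 to compound 2 (0.27 log units; that floor lies within the scatter), whose floor lies within the scatter. Compound 4 is expected near 20000 nM, between 8000 nM and 50000 nM, in this assay.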

Compound 4, half-maximal inhibitory concentration: 34200 nM
Beside the measured number, compound 4's estimate is 1.7-fold (0.23 log units) below it; the measured number falls inside the stated range.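

On the second core, hydroxycarbamoyl replaced by (hydroxycarbamoyl)methyl on a saturated chain carbon, four bonds along the chain from an aromatic nitrogen, gives a 1.0-fold higher number from compound 3 to compound 4 (0.01 log units; within the scatter) in this assay, so this pair shows no measurable effect of the change on this core. Set beside the first core, the comparison stays undecided: the same change on two cores in this assay, an at least 1.9-fold lower number (0.27 log units; that floor lies within the scatter) from compound 1 to compound 2 and a 1.0-fold higher number (0.01 log units; within the scatter) from compound 3 to compound 4; the limit leaves it open whether they differ This does not show that the change behaves differently on the two cores, because the earlier step has only a floor, with compound 1 standing at a limit of the assay and not at a number: the limit of > 50000 nM in this assay, at which 1 of the 4 values shown sits.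

As far as these compounds go, what a longer chain would give on either core remains open, as does the effect of replacing the hydroxycarbamoyl end with a carboxylic acid or an amine. From the compounds shown here alone, whether the change carries from one core to the other also stays open for as long as compound 1 is known only as a limit.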